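Bombesin receptor subtype-3 agonists: cyclopropyl for 3-fluorophenyl

A few compounds are considered here, and "the series" means these few. Any claim that something is new, unique, unknown or untested is made for them only; others in the source may bear on it.

Compound 1 `O=C(O)c1ccccc1-c1ccc(CCc2ncc(C3CCCCC3)[nH]2)cc1`: 375 nM
Compound 2 `O=C(O)c1ccccc1-c1ccc(CCc2ncc(Cc3cccc(F)c3)[nH]2)cc1`: 159 nM

Among the compounds with values here, in an in vitro functional assay on cells for agonist activity at Bombesin receptor subtype-3 (Homo sapiens), read by luminescence and calcium flux (a higher number here means that more compound is needed for the effect, a lower number that less compound is needed), compound 2 gives the lower of the two numbers so far, and its nearest neighbour is compound 1 with 375 nM. Within the data shown here, the one measured step, a 2.4-fold lower number from compound 1 to compound 2 (0.37 log units; beyond the scatter), came from 3-fluorobenzyl in place of cyclohexyl on an aromatic carbon and was beyond the scatter.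

Compound 3 `O=C(O)c1ccccc1-c1ccc(CCc2ncc(CC3CC3)[nH]2)cc1` carries the change (cyclopropyl in place of 3-fluorophenyl on a saturated chain carbon bound to an aromatic carbon). Among the measured compounds shown here, the only step that bears on it runs the other way in kind: it replaced a non-aromatic ring of carbon only with a group holding a six-membered aromatic ring, and that step lowered the number in this assay by a modest amount. For the measured compounds named here, compound 3 now gives up the aromatic ring again for a three-membered non-aromatic ring, so a move back toward a higher number seems more likely than a further lowering, though with only one step as a guide the size is uncertain. For compound 3 the expected step is a 3.1-fold higher number from compound 2 to compound 3 (0.50 log units; beyond the scatter), and the estimate in this assay is 500 nM, with a range from 160 nM to 1600 nM.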

Compound 3, half-maximal effective concentration: 1000 nM
Estimate against measurement, compound 3: 2.0-fold (0.30 log units) below; the range from low to high includes it.
By their numbers in this assay, from the lowest: compound 2; then compound 1; then compound 3.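

In this assay, replacing the 3-fluorophenyl with cyclopropyl gives a 6.3-fold higher number from compound 2 to compound 3 (0.80 log units; beyond the scatter), so the chain carbon bound to an aromatic carbon does not carry these two groups equally. The second new comparison gives a 2.7-fold higher number from compound 1 to compound 3 (0.43 log units; beyond the scatter), with cyclopropylmethyl in place of cyclohexyl on an aromatic carbon, which shows that this position also separates two groups that have no aromatic ring. Among these three compounds, the only one with an aromatic ring in this group, compound 2, has the lowest number, while the smallest group, in compound 3, has the highest, but one compound per group is too little to establish a trend, and nothing measured here bears on why the numbers move as they do.

The compounds shown leave open whether the lower number of compound 2 depends on the fluorine or on the aromatic ring itself, a question that a plain phenyl on the same saturated chain carbon would address. They also leave open how a cyclohexyl or a pyridine ring would behave on that carbon, and so whether ring size or ring type matters more.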